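Swapping an aryl group for isobutyl on a lactam nitrogen

The source may report more compounds than this note shows. Statements on the series, on what has been measured and on what is new or still open speak of the compounds shown alone.

Measured compounds:
compound 1 `O=c1oc2ccccc2n1Cc1nc(-c2cccc(Cl)c2)no1` – 2100 nM
compound 2 `O=C1CC(c2nc(-c3cccc(Cl)c3)no2)CN1c1cccc(Cl)c1` – 1100 nM

In an in vitro functional assay on HEK293-A cells for negative allosteric modulation of metabotropic glutamate receptor 5 (Homo sapiens), read by FLIPR and calcium flux (a lower number here means a stronger inhibitor, a higher number a weaker inhibitor), compound 2 gives 1100 nM, the lowest of the two numbers, while compound 1 gives 2100 nM; the gap between compound 2 and compound 1 lies within the scatter, so neither can be called the stronger inhibitor. Compound 3 `CC(C)CN1CC(c2nc(-c3cccc(Cl)c3)no2)CC1=O` has not been measured. It differs from compound 2 in one place: isobutyl in place of 3-chlorophenyl on an amide-type nitrogen in a ring. Going by the values given here, no measured pair shows the effect of such a change, so the expectation rests on the change alone. A step toward a weaker inhibitor of moderate size is expected in this assay, a 3.6-fold higher number from compound 2 to compound 3 (0.56 log units; beyond the scatter). Compound 3 is expected to give about 4000 nM, within 1200 nM to 15000 nM.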

Compound 3, half-maximal inhibitory concentration: 920 nM
Beside the measured number, compound 3's estimate is 4.3-fold (0.64 log units) above it; the measured number lies below the stated range.
By their numbers in this assay, from the lowest: compounds 3, 2 and 1 (each within the scatter of the next, the first and the last beyond it).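

On the amide-type nitrogen in a ring, isobutyl in place of 3-chlorophenyl gives a 1.2-fold lower number from compound 2 to compound 3 (0.08 log units; within the scatter) in this assay. This pair shows that, at this position, an open carbon chain with no ring can stand in for the chlorinated aromatic ring with no change that this assay can resolve. Nothing measured here gives a reason for this. Still open, on these data alone, is how far this tolerance extends: whether a longer chain, a cyclohexyl ring, a chain carrying an amine, or simply the amide hydrogen on this nitrogen would read the same.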